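The source may report more compounds than this note shows. Statements on the series, on what has been measured and on what is new or still open speak of the compounds shown alone.

Compound 1 `O=S(=O)(Nc1ccc(-c2nc3ccccc3o2)cc1)c1cccs1` gives 63000 nM in an assay on cells for inhibition of HSP60/HSP10 (Homo sapiens), with a stated time of 60 min; a higher number here means a weaker inhibitor, a lower number a stronger inhibitor.
Compound 2 `O=S(=O)(Nc1ccc(-c2nc3cc(NS(=O)(=O)c4ccccc4F)ccc3o2)cc1)c1ccccc1F` gives 57000 nM in this assay.
Compound 3 `C=Cc1ccc(S(=O)(=O)Nc2ccc3oc(-c4ccccc4)nc3c2)cc1` reaches only a limit in this assay, > 100000 nM.

Among the two numbers in this assay, compound 1 stands alongside compound 2, the two values lying within the scatter of each other. Compound 3 sits at a limit of the assay (the limit of > 100000 nM in this assay, at which 1 of the 3 values shown sits). Compound 4 `COc1ccccc1S(=O)(=O)Nc1ccc(-c2nc3ccccc3o2)cc1` has not yet been measured; it differs from compound 1 in one place (2-methoxyphenyl in place of thiophen-2-yl on a sulfonyl sulfur). Among the measured compounds shown here, no step between measured compounds bears on this change, so it is expected to shift the value by no more than the scatter, in no settled direction, and the estimated step is a 1.1-fold lower number from compound 1 to compound 4 (0.02 log units; within the scatter). Compound 4 is therefore expected to give about 60000 nM, within 25000 nM to 150000 nM.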

Compound 4, half-maximal inhibitory concentration: > 100000 nM
Compound 4 ended at the assay's limit (the forecaster's own chance of this, stated with the estimate: 30%); at least 1.6-fold (0.22 log units) between middle value and limit.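

Among the compounds shown here, replacing thiophen-2-yl with 2-methoxyphenyl on a sulfonyl sulfur gives the first reading at this position in this assay, and that reading is only a floor: an at least 1.5-fold higher number from compound 1 to compound 4 (0.20 log units; that floor lies within the scatter). Compound 4 gives > 100000 nM, which is a limit and not a number. It therefore joins the values that have no measured number: the limit of > 100000 nM in this assay, at which 2 of the 4 values shown sit.

The compounds shown leave open how large this step really is, and whether it goes beyond the scatter. They also leave open what an unsubstituted phenyl, an amine or a carboxylic acid at this position would give.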